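This account rests on a few compounds, and the source may have more. Where it says the series, first, only, none or still open, it means among the compounds named here.

Measured so far:
- Compound 1, `COc1ccc2ccc(=O)oc2c1C1=NN(C(N)=O)C(c2ccc(SC)cc2)C1`: 18 nM
- Compound 2, `COc1ccc2ccc(=O)oc2c1C1=NNC(c2ccc(SC)cc2)C1`: 10 nM

Both compounds were tested in a functional assay on HepG2 cells (Homo sapiens) for cytotoxicity, read by MTT assay, with a stated time of 72 h; on this read-out lower numbers stand for stronger inhibition and higher numbers for weaker inhibition. Compound 2 stands at the lowest of the two numbers shown, with compound 1 as its only neighbour, and the step of a 1.8-fold lower number from compound 1 to compound 2 (0.26 log units; within the scatter) shows that the two values cannot be told apart with confidence.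

Compound 3, `COc1ccc2ccc(=O)oc2c1C1=NN(c2ccccc2)C(c2ccc(SC)cc2)C1`, has not yet been measured. It differs from compound 2 by phenyl in place of hydrogen on an amine nitrogen in a ring. For the measured compounds named here, the only measured step that touches the same place on the shared core is the exchange of carbamoyl for hydrogen, a 1.8-fold lower number from compound 1 to compound 2 (0.26 log units; within the scatter), which left the number essentially unchanged. Going by the values given here, a phenyl group at this nitrogen has not been tried in any measured compound, so the data give no direct guide to its effect; the one comparison available suggests that this position tolerates a change of substituent without a clear shift. A step of no more than the scatter, in either direction, is therefore expected in this assay.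

For compound 3 the expected step is a 1.5-fold higher number from compound 2 to compound 3 (0.18 log units; within the scatter). Compound 3 is estimated at 15 nM, with a range from 5 nM to 45 nM in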

Compound 3, half-maximal inhibitory concentration: 78 nM
For compound 3 the middle estimate is 5.2-fold (0.72 log units) below the measured one; measured number above the stated range.
By their numbers in this assay, from the lowest: compounds 2 and 1 (each within the scatter of the next); then compound 3.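

In this assay phenyl in place of hydrogen on the amine nitrogen in the ring brings a 7.8-fold higher number from compound 2 to compound 3 (0.89 log units; beyond the scatter) and phenyl in place of carbamoyl at the same nitrogen brings a 4.3-fold higher number from compound 1 to compound 3 (0.64 log units; beyond the scatter) and so both steps point the same way, towards weaker inhibition. This position is therefore not indifferent to what it carries: hydrogen and carbamoyl could not be told apart here, whereas phenyl clearly stands apart from both. No measurement available here bears on what lies behind this loss.

The compounds shown leave open whether the loss belongs to the phenyl ring itself or would also appear with other carbon groups on this nitrogen, such as a methyl, an ethyl or a benzyl group. They also leave open whether a phenyl ring carrying a further group, such as a methoxy group or a fluorine atom, would recover any of the lost inhibition or lose more.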